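Propyl to isobutyl branching repeated on a second core

A few compounds are considered here, and "the series" means these few. Any claim that something is new, unique, unknown or untested is made for them only; others in the source may bear on it.

Compound 1 `CCCOC(=O)C1=C(C)NC(=S)NC1c1ccoc1` gives 45% in an assay on membranes from HEK293 cells for displacement of a labelled ligand from adenosine receptor A2b (Homo sapiens), read by scintillation counting, with a stated time of 30 min, tested at 1 uM; a higher number here means more inhibition at the concentration tested (going by the name of the read-out), a lower number less inhibition. Compound 2 `CC1=C(C(=O)OCC(C)C)C(c2ccoc2)NC(=S)N1` carries the change methyl in place of hydrogen on a saturated chain carbon bound to two saturated chain carbons and gives 1% in this assay, a step of a number 44 percentage points lower from compound 1 to compound 2 (beyond the scatter). Compound 3 `CCCOC(=O)C1=C(C)N(C)C(=O)NC1c1ccco1` has a different core; the difference between its core and that of compound 1 is not broken down here. In this assay compound 3 gives 23%, which puts it second of the three measured numbers, above compound 2 and below compound 1.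

Compound 4 `CC1=C(C(=O)OCC(C)C)C(c2ccco2)NC(=O)N1C` has not been measured. It differs from compound 3 by methyl in place of hydrogen on a saturated chain carbon bound to two saturated chain carbons. The place of this change is the same, word for word, as in the pair of compound 1 and compound 2, so it is the same change, occurring twice among the compounds shown, once on each core.

The step from compound 3 to compound 4 is expected to be about a number 18 percentage points lower from compound 3 to compound 4 (beyond the scatter). Among the compounds with values here, this expectation rests on the earlier step, a number 44 percentage points lower from compound 1 to compound 2 (beyond the scatter), which on the first core brought the number to near the bottom of the scale; compound 3 starts lower than compound 1, so the room for a drop of the same size is smaller, and the number can hardly fall much below the floor. Whether the second core answers the branching in the same way is the open point.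

Compound 4 is therefore expected to give 5% in this assay, most likely between 0% and 20%.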

Compound 4, a percentage reported as inhibition, at one concentration (the size of the read-out at that concentration, not a potency): 4%
The estimate for compound 4 lay 1 percentage points above the measured number, within the range that was stated.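

Working notes on the branching step: propyl to isobutyl lowers the number in this assay on both cores, with a number 44 percentage points lower from compound 1 to compound 2 (beyond the scatter) on the first and a number 19 percentage points lower from compound 3 to compound 4 (beyond the scatter) on the second, so the direction of the change carries from one core to the other in these two pairs. The size does not carry over unchanged: the same change on two cores in this assay, a number 44 percentage points lower (beyond the scatter) from compound 1 to compound 2 and a number 19 percentage points lower (beyond the scatter) from compound 3 to compound 4, 25 percentage points apart, beyond the scatter of two such steps This does not show that the two cores respond differently in any deeper sense, since both steps end close to the bottom of the scale, with compound 2 at 1% and compound 4 at 4%, and a read-out at one concentration cannot say how much further either number would have fallen, so two pairs support a shared direction and no general rule for the series.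

Open, going by these compounds, is whether a longer straight chain, or a carboxylic acid or an amine at the end of the propoxy chain, would keep the number or lower it in the same way on each core. Within the data shown here, also open is which of the several differences between the core of compound 1 and the core of compound 3 sets their starting numbers, as no single-place pair separates them.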